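This account rests on a few compounds, and the source may have more. Where it says the series, first, only, none or still open, it means among the compounds named here.

The measured compounds in a functional assay on U-87MG ATCC cells for inhibition, with U-87 MG (Homo sapiens) as the target, read by MTT assay, with a stated time of 48 h; a lower number here means a stronger inhibitor, a higher number a weaker inhibitor:

compound 1 `COc1cc(/C=N/Nc2nc(-c3ccc(Br)cc3)cs2)cc(Br)c1OC` gives 27900 nM
compound 2 `COc1cc(/C=N/Nc2nc(-c3ccccc3)cs2)cc(Br)c1OC` gives 74100 nM
compound 3 `COc1cc(/C=N/Nc2nc(-c3ccc(F)c(F)c3)cs2)cc(Br)c1OC` gives 26300 nM

Among these three, compound 1 holds the second highest number, with compound 3 nearest to it and compound 2 furthest away. The two changes seen so far both sit on the aryl ring attached to the shared core: a 2.7-fold higher number from compound 1 to compound 2 (0.42 log units; beyond the scatter), and a 2.8-fold lower number from compound 2 to compound 3 (0.45 log units; beyond the scatter), while a 1.1-fold lower number from compound 1 to compound 3 (0.03 log units; within the scatter). Halogen changes on that ring thus shift the number only modestly.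

Compound 4 `COc1cc(/C=N/Nc2nc(-c3ccc(Br)cc3)cs2)c(Br)c(Br)c1OC` differs from compound 1 in another part of the molecule: bromo in place of hydrogen on an aromatic carbon. Among the measured compounds shown here, no measured pair touches this ring, so nothing in the data bears directly on the step. For the measured compounds named here, the only guidance is indirect: the modest size of the halogen steps on the other ring, as in a 2.7-fold higher number from compound 1 to compound 2 (0.42 log units; beyond the scatter), suggests that a single added bromo is unlikely to move the number by much. The step is therefore expected to be small, with no clear direction, and most likely within the scatter.

For compound 4 the estimated step is a 1.3-fold lower number from compound 1 to compound 4 (0.10 log units; within the scatter). Compound 4 is expected to give about 22000 nM, in the range 8000 nM to 60000 nM.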

Compound 4, half-maximal inhibitory concentration: > 100000 nM
Compound 4 was reported as a limit; the forecaster's own chance of this, stated with the estimate: 5%; middle value at least 4.5-fold (0.65 log units) away from the limit.
By their numbers in this assay, from the lowest: compounds 3 and 1 (each within the scatter of the next); then compound 2. At a limit, above all of these: compound 4.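

In this assay compound 4 is reported only as a limit, > 100000 nM. The position, on the methoxy-bearing ring, ortho to a bromo group and para to a methoxy group, proves not to be indifferent to substitution: bromo in place of hydrogen here gives an at least 3.5-fold higher number from compound 1 to compound 4 (0.55 log units; beyond the scatter), so a single added atom moves the number beyond the scatter, and in the direction of a weaker inhibitor, while the change on the other aryl ring from 4-bromophenyl to 3,4-difluorophenyl gives only a 1.1-fold lower number from compound 1 to compound 3 (0.03 log units; within the scatter). The earlier compounds varied that other ring alone, so this is the first sign that the methoxy-bearing ring matters, although the true size of the step stays unknown, as only a limit is available: the limit of > 100000 nM in this assay, at which 1 of the 4 values shown sits.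

The compounds shown rest on this one change at this position, so they cannot tell whether any group there raises the number or only bromo does. On these data alone, a fluoro, a methyl, a hydroxy or an amine in the same place could separate these two readings, and how far the number truly rises with bromo remains open.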